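Replacing the chloro of compound 2 with a benzylamino-methyl chain

The compounds below may be only part of what the source reports. "The series", "measured", "known", "first", "only" and "open" are said of these compounds alone.

The series rests on a shared core carrying a trimethoxyanilino group. Compound 1 `COc1cc(Nc2nc(Cl)cc3c(C(C)C)n[nH]c23)cc(OC)c1OC` bears an isopropyl on the core, and in an assay on Flp-In-CHO cells for binding affinity to adenosine receptor A3 (Homo sapiens), using Schild analysis (a lower number here means tighter binding, a higher number weaker binding), compound 1 gives 550 nM. Compound 2 `COc1cc(Nc2nc(Cl)cc3c(-c4ccccc4)n[nH]c23)cc(OC)c1OC` carries a phenyl instead, and in this assay compound 2 gives 89.1 nM. Among the measured compounds shown here, the one measured step, a 6.2-fold lower number from compound 1 to compound 2 (0.79 log units; beyond the scatter), concerns the phenyl-for-isopropyl exchange and is the only comparison available; compound 2 therefore stands lowest of the two numbers, with compound 1 as its nearest neighbour at the higher value.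

Compound 3 `COc1cc(Nc2nc(CNCc3ccccc3)cc3c(-c4ccccc4)n[nH]c23)cc(OC)c1OC` differs from compound 2 by (benzylamino)methyl in place of chloro on an aromatic carbon. For the measured compounds named here, no measured step touches this position or this kind of exchange, so the direction cannot be drawn from the two values shown; the step from compound 2 to compound 3 is expected to be a 1.7-fold higher number from compound 2 to compound 3 (0.23 log units; within the scatter), with wide uncertainty. For compound 3 in this assay the dissociation constant is estimated at 150 nM, within 30 nM to 800 nM.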

Compound 3, dissociation constant: 158 nM
Beside the measured number, compound 3's estimate is 1.1-fold (0.02 log units) below it; measured number inside the range.
By their numbers in this assay, from the lowest: compounds 2 and 3 (each within the scatter of the next); then compound 1.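

Among the compounds shown here, the step of a 1.8-fold higher number from compound 2 to compound 3 (0.25 log units; within the scatter) in this assay is the first reading at this position, next to the ring nitrogen, and it shows that chloro and (benzylamino)methyl cannot be told apart here. The exchange adds a six-membered aromatic ring, a hydrogen-bond donor and a hydrogen-bond acceptor, yet compound 3 remains within the scatter of compound 2, whereas the earlier step concerned only the phenyl-for-isopropyl exchange. No evidence bears on why the two numbers lie so close.

On these data alone, whether the benzyl ring or the chain nitrogen contributes anything to the number of compound 3 remains open, since a single chain cannot separate the two. As far as these compounds go, how a simple amine, a methoxy group, a carboxylic acid or a longer chain would read at this position also stays unknown.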